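A few compounds are considered here, and "the series" means these few. Any claim that something is new, unique, unknown or untested is made for them only; others in the source may bear on it.

Compound 1 `O=C(O)CC[C@H]1CCc2cc(-c3cc(OC(F)(F)F)cc(Cl)c3F)ccc2O1` gives 2200 nM in a functional assay on HEK293 cells for agonist activity at Free fatty acid receptor 1 (Homo sapiens), read by HTRF and inositol phosphate accumulation, with a stated time of 60 min; on this read-out higher numbers stand for an effect only at larger amounts of compound and lower numbers for an effect already at smaller amounts.
Compound 2 `COc1cc(O[C@H]2C[C@H](OC)C2)cc(-c2ccc3c(c2)CC[C@H]([C@@H]2C[C@H]2C(=O)O)O3)c1F` gives > 10000 nM in this assay.
Compound 3 `COc1cc(OC2CCC2)nc(-c2ccc3c(c2)CC[C@H]([C@@H]2C[C@H]2C(=O)O)O3)c1F` gives > 10000 nM in this assay.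

For the measured compounds named here, compound 1 stands apart as the only compound with a number. The value of compound 2 is a limit of the assay, not a number. The value of compound 3 is likewise a limit, a pattern summed up by the limit of > 10000 nM in this assay, at which 2 of the 3 values shown sit. Going by the values given here, no measured pair differs in a single place, so no step can be read from the data.

Compound 4 `O=C(O)CC[C@H]1CCc2cc(-c3cc(OC4CCC4)cc(Cl)c3F)ccc2O1` differs from compound 1 by cyclobutyl in place of trifluoromethyl on an oxygen on an aromatic ring. Among the compounds with values here, with no measured step to lean on, the expected change from compound 1 to compound 4 is a 1.1-fold higher number from compound 1 to compound 4 (0.06 log units; within the scatter), a step no larger than the scatter. Compound 4 is therefore estimated at 2500 nM, within 800 nM to 8000 nM.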

Compound 4, half-maximal effective concentration: > 10000 nM
Compound 4 was reported as a limit; the forecaster's own chance of this, stated with the estimate: 20%; middle value at least 4.0-fold (0.60 log units) from the limit.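

For the compounds shown here, this is the first change in one place that can be read, and it shows that the group on this oxygen matters: going from trifluoromethoxy to cyclobutyloxy gives an at least 4.5-fold higher number from compound 1 to compound 4 (0.65 log units; beyond the scatter). The two groups have the same count of heavy atoms and no hydrogen-bond donors or acceptors, so these counts do not separate them. Compound 4 carries a limit of the assay, not a number: the limit of > 10000 nM in this assay, at which 3 of the 4 values shown sit.

Still open, on these data alone, is whether an ethyl or a cyclopropyl group on this oxygen would give a measurable number. How far compound 4 lies past its limit cannot be read.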